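Compound 3: amino in place of nitro

The compounds below may be only part of what the source reports. "The series", "measured", "known", "first", "only" and "open" are said of these compounds alone.

Measured in a functional assay on HT-29 cells (Homo sapiens) for antiproliferative activity, read by MTT assay, with a stated time of 72 h; a lower number here means a stronger inhibitor, a higher number a weaker inhibitor:
compound 1 `COc1ccc(-n2ccnc2-c2cc(OC)c(OC)c(OC)c2)cc1[N+](=O)[O-]` gives 600 nM
compound 2 `COc1ccc(C(=O)Nc2cc(OC)c(OC)c(OC)c2)cc1[N+](=O)[O-]` gives 8300 nM
compound 3 `COc1ccc(C(=O)Oc2cc(OC)c(OC)c(OC)c2)cc1[N+](=O)[O-]` gives > 100000 nM (a limit, not a number)

Compound 3 sits at the limit of > 100000 nM in this assay, at which 1 of the 3 values shown sits, and that entry is a limit and not a number. Compound 4 `COc1ccc(C(=O)Oc2cc(OC)c(OC)c(OC)c2)cc1N` differs from compound 3 in one place: amino in place of nitro on an aromatic carbon (amino in place of nitro on an aromatic carbon, ortho to a methoxy group). Among the compounds with values here, no measured pair isolates this exchange, so any figure for it is a judgement. A modest gain in this assay is expected, and a reading that stays at the limit remains possible. The expectation is anchored by compound 2 (8300 nM) and compound 1 (600 nM), which show that numerical readings occur in this series. The expected size is an at least 3.3-fold lower number from compound 3 to compound 4 (0.52 log units; beyond the scatter) in the direction of stronger inhibition. For compound 4 the estimated value is 30000 nM with an expected range from 3000 nM to 100000 nM in this series.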

Compound 4, half-maximal inhibitory concentration: > 100000 nM
Compound 4: only a limit was reported (the forecaster's own chance of this, stated with the estimate: 35%); middle value at least 3.3-fold (0.52 log units) from the limit.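

No step can be read from compound 3 to compound 4, since both entries are limits and not numbers: the limit of > 100000 nM in this assay, at which 2 of the 4 values shown sit.

The compounds shown leave open what amino in place of nitro on an aromatic carbon does in a compound that gives a number rather than a limit.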